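A few compounds are considered here, and "the series" means these few. Any claim that something is new, unique, unknown or untested is made for them only; others in the source may bear on it.

Compound 1, `COc1cc(NC(C)CCCNC(=O)Nc2cccc(Cl)c2)c2ncccc2c1`: 21000 nM
Compound 2, `COc1cc(NC(C)CCCNC(=O)Nc2ccc(Br)cc2)c2ncccc2c1`: 25000 nM
Compound 3, `COc1cc(NC(C)CCCNC(=O)NNC(=O)Nc2ccc(F)cc2)c2ncccc2c1`: >= 250000 nM

In a functional assay on MOLT-4 cells (Homo sapiens) for inhibition, read by MTT assay, with a stated time of 72 h (a higher number here means a weaker inhibitor, a lower number a stronger inhibitor), compound 1 gives 21000 nM and compound 2 gives 25000 nM; the step of a 1.2-fold higher number from compound 1 to compound 2 (0.08 log units; within the scatter). For compound 3 this assay reports only a limit, >= 250000 nM, and not a number. Compound 3 thus stands as the weakest of the three, since the steps of an at least 11-fold higher number from compound 1 to compound 3 (1.07 log units; beyond the scatter) and an at least 10-fold higher number from compound 2 to compound 3 (1.00 log units; beyond the scatter) both lie beyond the scatter, and its value is the limit of >= 250000 nM in this assay, at which 1 of the 3 values shown sits.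

Compound 4, `COc1cc(NC(C)CCCNC(=O)NNC(=O)Nc2ccc(C(F)(F)F)cc2)c2ncccc2c1`, is not yet measured. It differs from compound 3 by trifluoromethyl in place of fluoro on an aromatic carbon. For the measured compounds named here, no measured step changes a group on the phenyl ring within the pair of compounds that carry the ((4-fluorophenyl)carbamoyl)amino unit; the only measured exchange on that ring, a 1.2-fold higher number from compound 1 to compound 2 (0.08 log units; within the scatter), is within the scatter, and the two large steps concern the linker, not the ring substituent. Compound 4 is therefore expected to give no step beyond the scatter in this assay, staying at the limit. Compound 4 is estimated at 250000 nM, in a range from 100000 nM to 600000 nM. The expected step is a number no higher from compound 3 to compound 4 (the limit leaves the size open).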

Compound 4, half-maximal inhibitory concentration: 24000 nM
Compound 4: middle estimate off by 10-fold (1.02 log units), on the high side; measured number outside the range, below it.
By their numbers in this assay, from the lowest: compounds 1, 4 and 2 (each within the scatter of the next). At a limit, above all of these: compound 3.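

In this assay, the substituent on this aromatic carbon, para to a large group, proves able to move the number: trifluoromethyl in place of fluoro gives an at least 10-fold lower number from compound 3 to compound 4 (1.01 log units; beyond the scatter). For the compounds shown here, the only earlier change on a phenyl ring, 4-bromophenyl in place of 3-chlorophenyl, gave a 1.2-fold higher number from compound 1 to compound 2 (0.08 log units; within the scatter), so the ring looked insensitive, but that pair lacks the ((4-fluorophenyl)carbamoyl)amino unit of compound 3, and its flat result does not carry over to the compounds with that longer linker. The value of compound 3 is a limit and not a number, which leaves the full size of the new step open: the limit of >= 250000 nM in this assay, at which 1 of the 4 values shown sits.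

On these data alone, it remains open whether a chlorine, a methyl or a methoxy at this place would give a number close to that of compound 4 or stay at a limit like compound 3. As far as these compounds go, it is equally open whether a trifluoromethyl on the phenyl ring of compound 1 would change the number there, or whether this substituent matters only with the longer linker.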